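The source may hold more compounds than are shown below. What is called first, only, known or untested is meant among the compounds shown, and "the series" means these compounds.

The two measured compounds and their values:

compound 1 `Cn1nc(-c2ccnc(Nc3ccc(O)cc3)n2)c2ccccc21` — 8430 nM
compound 2 `Cn1nc(-c2ccnc(Nc3ccc(S(N)(=O)=O)cc3)n2)c2ccccc21` — 2280 nM

In a functional assay on HCT-116 cells (Homo sapiens) for antiproliferative activity, read by MTT assay, with a stated time of 72 h (on this read-out higher numbers stand for weaker inhibition of growth and lower numbers for stronger inhibition of growth), compound 1 gives 8430 nM while compound 2 gives 2280 nM. Going by the values given here, the two differ in one place, and the step of a 3.7-fold lower number from compound 1 to compound 2 (0.57 log units; beyond the scatter) brings compound 2 to the lowest number of the two, with compound 1 as the only neighbour. Compound 3 `CCCn1nc(-c2ccnc(Nc3ccc(S(N)(=O)=O)cc3)n2)c2ccccc21` keeps the whole of compound 2 apart from one change: ethyl in place of hydrogen on a saturated chain carbon bound to an aromatic nitrogen. Put another way, the methyl on the shared core is extended to a propyl. Among the compounds with values here, no measured step touches this position; the only step available, from compound 1 to compound 2, concerns a different part of the molecule and says nothing about a longer chain on the nitrogen of the shared core. Without a guide, the expected step of a 1.1-fold lower number from compound 2 to compound 3 (0.06 log units; within the scatter) is set close to no change, with a range wide enough to take in a modest gain or loss. Compound 3 is therefore estimated at 2000 nM, between 700 nM and 6000 nM.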

Compound 3, concentration for 50% growth inhibition: 6740 nM
Compound 3: the middle estimate sits 3.4-fold (0.53 log units) below what was measured, outside the stated range (above it).
By their numbers in this assay, from the lowest: compound 2; then compounds 3 and 1 (each within the scatter of the next).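

In this assay, extending methyl to propyl on the aromatic nitrogen gives a 3.0-fold higher number from compound 2 to compound 3 (0.47 log units; beyond the scatter), so the longer chain goes with weaker inhibition of growth. This shows that the chain at this position is not a neutral part of the molecule: adding ethyl in place of hydrogen at its saturated carbon is enough to produce a change beyond the usual scatter, something the earlier step, made elsewhere on the molecule, could not reveal. The data give no explanation for this loss.

Going by these compounds, a single pair gives only a direction for this one change, so it remains open whether the number rises steadily with chain length or whether propyl is a special case, which an ethyl or butyl chain on the same nitrogen would help to settle. Also open, on these data alone, are the effect of removing the methyl to leave hydrogen, the effect of a chain ending in an amine or a carboxylic acid, and whether propyl would cause a similar step with hydroxy in place of sulfamoyl.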